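The source may hold more compounds than are shown below. What is called first, only, known or untested is meant among the compounds shown, and "the series" means these compounds.

Two pairs of furan-to-thiophene analogues carry an amidine at one end and a substituted phenyl at the other. Compound 1 `N=C(N)c1ccc(-c2ccc(-c3ccc(F)cc3)o2)o1` gives 10600 nM in an ADME assay on WI-38 cells (Homo sapiens) for cytotoxicity, read by MTT assay, with a stated time of 48 h; on this read-out lower numbers stand for stronger inhibition and higher numbers for weaker inhibition. Compound 2 `COc1ccc(-c2ccc(-c3ccc(C(=N)N)o3)o2)cc1` differs from compound 1 by methoxy in place of fluoro on an aromatic carbon. In this assay compound 2 gives 72900 nM, a change of a 6.9-fold higher number from compound 1 to compound 2 (0.84 log units; beyond the scatter). Compound 3 `N=C(N)c1ccc(-c2ccc(-c3ccc(F)cc3)s2)s1` gives 13300 nM in this assay; its value and that of compound 1 lie within the scatter of each other, and the difference between the two cores is not broken down here. Compound 4 `COc1ccc(-c2ccc(-c3ccc(C(=N)N)s3)s2)cc1` is not yet measured; it differs from compound 3 by methoxy in place of fluoro on an aromatic carbon, the same change seen from compound 1 to compound 2. The expected step is a 6.0-fold higher number from compound 3 to compound 4 (0.78 log units; beyond the scatter), because the same change gave a 6.9-fold higher number from compound 1 to compound 2 (0.84 log units; beyond the scatter) on the other core. Compound 4 is therefore expected at 80000 nM, between 35000 nM and 180000 nM.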

Compound 4, half-maximal inhibitory concentration: 12900 nM
For compound 4 the middle estimate is 6.2-fold (0.79 log units) above the measured one; the whole stated range lies above it.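

In this assay, the step on the core of compound 3 is a 1.0-fold lower number from compound 3 to compound 4 (0.01 log units; within the scatter), so methoxy in place of fluoro on an aromatic carbon does not behave as a transferable increment in this series. The two steps set side by side differ: the same change on two cores in this assay, a 6.9-fold higher number (0.84 log units; beyond the scatter) from compound 1 to compound 2 and a 1.0-fold lower number (0.01 log units; within the scatter) from compound 3 to compound 4, 7.1-fold (0.85 log units) apart, beyond the scatter of two such steps. This rests on a single pair per core, so it shows that the step depends on the core in these two cases, but not why, nor how general that dependence is.

Going by these compounds, it remains open whether an amine, a chloro group or a longer alkoxy chain at the same position would also give different steps on the two cores. On these data alone, whether the amidine end contributes to the difference is also open.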